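The source may report more compounds than this note shows. Statements on the series, on what has been measured and on what is new or still open speak of the compounds shown alone.

Measured compounds:
Compound 1, `Cc1nnc(SCC(=O)N/N=c2/scc(-c3ccc(C#N)cc3)n2-c2ccccc2)s1`, "not determined" (no result reported).
Compound 2, `O=C(CSc1ncccn1)N/N=c1/scc(-c2ccc(F)cc2)n1-c1ccccc1`, 110 ug/mL.
Compound 3, `Cc1nnc(SCC(=O)N/N=c2/scc(-c3ccc([N+](=O)[O-])cc3)n2-c2ccccc2)s1`, "not determined" (no result reported).

Three compounds of this series were taken into a functional assay on C6 cells (Rattus norvegicus) for cytotoxicity, read by MTT assay, with a stated time of 24 h; a higher number here means a weaker inhibitor, a lower number a stronger inhibitor. Only compound 2 came out with a number, and in this assay compound 2 gives 110 ug/mL. Going by the values given here, compound 1 and compound 3 carry no result in this assay, so compound 3 stands nowhere on the numbers: there is no value of its own to place it against compound 2, and no step from it to any measured compound can be counted.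

Compound 4, `Cc1nnc(SCC(=O)N/N=c2/scc(-c3ccc(F)cc3)n2-c2ccccc2)s1`, is the next member and has not yet been measured. It differs from compound 3 in one place: fluoro in place of nitro on an aromatic carbon. The change is a fluoro in place of nitro on an aromatic carbon, para to a large group. Among the compounds with values here, since compound 3 has no number, no size or direction can be given for the step to compound 4 in this assay; the only footing is compound 2, which shares the fluorophenyl with compound 4.

Compound 4 is expected to land near compound 2, because compound 2 gives 110 ug/mL, and the estimate is 100 ug/mL with a range from 40 ug/mL to 250 ug/mL.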

Compound 4, half-maximal inhibitory concentration: 27.3 ug/mL
Compound 4: the middle estimate sits 3.7-fold (0.56 log units) above what was measured, outside the stated range (below it).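

With the 4-fluorophenyl held fixed, this assay records a 4.0-fold lower number from compound 2 to compound 4 (0.61 log units; beyond the scatter), which shows that the group on the sulfur matters in this series: in this one pair, 5-methyl-1,3,4-thiadiazol-2-yl gives a stronger inhibitor than pyrimidin-2-yl, and the difference lies beyond the scatter. On these data alone, the steps from compound 1 and compound 3 cannot be read, as neither has a number, so the result says nothing about the change from 4-nitrophenyl to 4-fluorophenyl, and the effect of the substituent on the aromatic carbon remains unknown. Nothing among the data shown explains why the number moves with the group on the sulfur.

The compounds shown rest this reading on a single pair, which leaves open whether the same step would appear with a group other than the 4-fluorophenyl on the core. They also leave open what a carboxylic acid or an amine would give on that aromatic carbon, and what an ethyl group would give in place of the methyl on the group attached to the sulfur.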